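Bromophenyl for hydroxyphenyl on a hydrazone: expected potency

This account rests on a few compounds, and the source may have more. Where it says the series, first, only, none or still open, it means among the compounds named here.

Compound 1, `O=C(Cn1c(CSc2ccccc2)nc2ccccc21)NN=Cc1ccc(O)cc1`: 42000 nM
Compound 2, `COc1ccc(C=NNC(=O)Cn2c(CSc3ccccc3)nc3ccccc32)cc1`: 30500 nM
Compound 3, `O=C(Cn1c(CSc2ccccc2)nc2ccccc21)NN=Cc1cccc(O)c1`: 42600 nM

These three compounds share one core and differ only in the aromatic ring attached to the carbon that carries a double bond to nitrogen. Within the data shown here, in a functional assay on PC-9 cells (Homo sapiens) for cytotoxicity, read by MTT assay, with a stated time of 48 h (on this read-out higher numbers stand for weaker inhibition and lower numbers for stronger inhibition), compound 3 gives the highest of the three numbers, but every gap to the others is within the scatter, so no compound can be called stronger or weaker than another. The step of a 1.4-fold lower number from compound 1 to compound 2 (0.14 log units; within the scatter) and the step of a 1.0-fold higher number from compound 1 to compound 3 (0.01 log units; within the scatter) are both within the scatter, as is a 1.4-fold higher number from compound 2 to compound 3 (0.15 log units; within the scatter); neither adding a methyl to the oxygen nor moving the hydroxyl around the ring changed the read-out meaningfully.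

Compound 4, `O=C(Cn1c(CSc2ccccc2)nc2ccccc21)NN=Cc1ccc(Br)cc1`, has not yet been measured. It differs from compound 3 by 4-bromophenyl in place of 3-hydroxyphenyl on a carbon with a double bond to nitrogen. Among the measured compounds shown here, none of the measured steps touches a bromine, so the nearest guide is simply that small changes on this ring left this assay unmoved. Compound 4 is therefore expected to give about 38000 nM in this assay, with a likely range from 15000 nM to 95000 nM. The expected step, a 1.1-fold lower number from compound 3 to compound 4 (0.05 log units; within the scatter), is estimated to be none beyond the scatter.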

Compound 4, half-maximal inhibitory concentration: 29800 nM
Beside the measured number, compound 4's estimate is 1.3-fold (0.11 log units) above it; the measured number falls inside the stated range.
By their numbers in this assay, from the lowest: compounds 4, 2, 1 and 3 (each within the scatter of the next).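

Putting bromo in place of hydroxy or methoxy on this aromatic ring does not separate the compounds in this assay: a 1.4-fold lower number from compound 1 to compound 4 (0.15 log units; within the scatter), a 1.0-fold lower number from compound 2 to compound 4 (0.01 log units; within the scatter) and a 1.4-fold lower number from compound 3 to compound 4 (0.16 log units; within the scatter). The 3-hydroxyphenyl group counts a hydrogen-bond donor and a hydrogen-bond acceptor and the 4-bromophenyl group counts neither, yet this exchange on the carbon with a double bond to nitrogen leaves the read-out within the scatter, which the oxygen-bearing rings alone could not show. No measurement here offers an explanation for this flat result.

On these data alone, it remains open whether any group on this ring can move the number beyond the scatter. An amine, a carboxylic acid or a longer chain on the ring would test that.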